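This account rests on a few compounds, and the source may have more. Where it says the series, first, only, none or still open, it means among the compounds named here.

Measured in a functional assay with Oryctolagus cuniculus as the target; on this read-out lower numbers stand for stronger inhibition and higher numbers for weaker inhibition:
- compound 1 `COc1ccc(-c2nc(/N=C(\N)NC3CCCCC3)sc2-c2ccc(OC)cc2)cc1`: > 1000 nM, a limit
- compound 2 `COc1ccc(-c2nc(CN(C)C)sc2-c2ccc(OC)cc2)cc1`: 96 nM
- compound 3 `COc1ccc(-c2nc(CN)sc2-c2ccc(OC)cc2)cc1`: > 100 nM, a limit

Within the data shown here, compound 3 has no number, and its only reading is the limit of > 100 nM in this assay, at which 1 of the 3 values shown sits. Compound 1 is likewise known only through (the limit of > 1000 nM in this assay, at which 1 of the 3 values shown sits).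

The next change leads to compound 4 `COc1ccc(-c2nc(C(N)=O)sc2-c2ccc(OC)cc2)cc1`: carbamoyl in place of aminomethyl on an aromatic carbon, on a five-membered aromatic ring with 1 nitrogen and 1 sulfur.

Among the measured compounds shown here, no measured step makes this exact exchange. Two measured steps change the group on this same aromatic carbon. One is an at least 10-fold lower number from compound 1 to compound 2 (1.01 log units; beyond the scatter), large and beyond the scatter. The other is a step that the two limits leave unreadable from compound 1 to compound 3, which the two limits leave unreadable. The step of an at least 1.0-fold higher number from compound 2 to compound 3 (0.01 log units; that floor lies within the scatter) has a floor within the scatter, so it fixes no size for the loss of the two methyl groups.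

For the measured compounds named here, the estimate therefore leans on compound 2 at 96 nM, the only true number, and on the large step of an at least 10-fold lower number from compound 1 to compound 2 (1.01 log units; beyond the scatter), which shows that this carbon can matter. A modest move to higher numbers is expected, without a confident size or direction, and the result may again be only a limit. The expected step is a step that the limit leaves unreadable from compound 3 to compound 4. For compound 4 the estimated value in this assay is 250 nM, with an expected range of 70 nM to 1000 nM.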

Compound 4, half-maximal inhibitory concentration: > 1000 nM
Compound 4 gave a limit, no number; the forecaster's own chance of this, stated with the estimate: 45%; middle value at least 4.0-fold (0.60 log units) away from the limit.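

In this assay, carbamoyl in place of (dimethylamino)methyl on this aromatic carbon gives an at least 10-fold higher number from compound 2 to compound 4 (1.01 log units; beyond the scatter), so carbamoyl is enough for a large step at this position, whereas the earlier large step involved the group of 10 heavy atoms in compound 1. Compound 4 is recorded only as a limit, a reading it shares with compound 1: the limit of > 1000 nM in this assay, at which 2 of the 4 values shown sit. The steps from compound 3 to compound 4 and from compound 1 to compound 4 cannot be read, so the direct exchange of aminomethyl for carbamoyl has no size.

The compounds shown leave open whether a true number at this carbon depends on the dimethylamino group, as compound 2 is the only compound with a number and compound 3, with aminomethyl, is known only as a limit. Also open, as far as these compounds go, is how dimethylcarbamoyl, which would separate the carbonyl from the two methyl groups, or a longer chain such as 2-(dimethylamino)ethyl, would read at this carbon in this assay.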